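Adding a hydroxymethyl to the outer ring of compound 2

The source may report more compounds than this note shows. Statements on the series, on what has been measured and on what is new or still open speak of the compounds shown alone.

Measured compounds:
- Compound 1, `O=C(O)CC/C=C\CO[C@H]1[C@@H](OCc2ccc(-c3ccccc3)cc2)CC[C@@H]1N1CCCCC1`: 31.6 nM; 50.1 nM (2 entries)
- Compound 2, `O=C(O)CC/C=C\CO[C@H]1[C@@H](OCc2ccc(-c3ccccc3)cc2)CC[C@@H]1N1CCCCCC1`: 39.8 nM

Both compounds share one core and differ only in the size of the saturated nitrogen ring at its end. In a functional assay for antagonist activity at thromboxane A2 receptor (Rattus norvegicus) (a higher number here means weaker binding, a lower number tighter binding), compound 1 gives 31.6 nM; 50.1 nM (2 entries), and the repeated entries for it, (the several entries of compound 1 in this assay, 31.6 nM; 50.1 nM (2 entries)), fall within the usual scatter of one another. In this assay, for the measured compounds named here, compound 2 gives 39.8 nM, which is the only number it has here, with one further entry that carries no single number. The values of compound 1 and compound 2 lie within the scatter of each other, so no order between them can be read.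

Compound 3, `O=C(O)CC/C=C\CO[C@H]1[C@@H](OCc2ccc(-c3ccc(CO)cc3)cc2)CC[C@@H]1N1CCCCCC1`, is not yet measured. It differs from compound 2 in one place: hydroxymethyl in place of hydrogen on an aromatic carbon, so that the outer phenyl becomes 4-(hydroxymethyl)phenyl. Going by the values given here, with no measured step of this kind to lean on, the change is expected to move the number little, in either direction, and not beyond the scatter. Compound 3 is therefore estimated at 40 nM, within 15 nM to 120 nM, an expected step of a 1.0-fold higher number from compound 2 to compound 3 (0.00 log units; within the scatter).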

Compound 3, dissociation constant: 50.1 nM
Estimate against measurement, compound 3: 1.3-fold (0.10 log units) below; the measured number falls inside the stated range.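

Until now the only variation shown lay in the saturated nitrogen ring, so the outer phenyl had no measured step of its own. In this assay, changing phenyl to 4-(hydroxymethyl)phenyl gives a 1.3-fold higher number from compound 2 to compound 3 (0.10 log units; within the scatter). For the compounds shown here, this is the first sign that this aromatic carbon, para to a large group, can carry hydroxymethyl, with its hydrogen-bond donor and acceptor, without a readable shift in the number, and a gap this size cannot be told apart from the spread of repeated entries for a single compound: the several entries of compound 1 in this assay, 31.6 nM; 50.1 nM (2 entries).

On these data alone, this single step speaks for hydroxymethyl alone, so it remains open whether an amine, a carboxylic acid or a longer chain ending in a hydroxyl group would be accepted on the same carbon just as well. As far as these compounds go, it also remains open whether hydroxymethyl would leave the number just as unmoved on compound 1, which has the smaller nitrogen ring, since a result on one core does not automatically carry over to its close relative.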